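Solubility of an amide pair and a thiazole analogue

The source may hold more compounds than are shown below. What is called first, only, known or untested is meant among the compounds shown, and "the series" means these compounds.

Compound 2 `O=C(Nc1cccc(-c2nc3ccccc3s2)c1)c1ccnc(Cl)c1` is the amide obtained from compound 1 `O=C(O)/C=C/C(=O)Nc1cccc(-c2nc3ccccc3s2)c1` by exchanging the 2-carboxyethenyl group for 2-chloropyridin-4-yl on the carbonyl carbon. In a physicochemical assay for solubility, in phosphate buffer, measured as kinetic solubility, with a stated time of 18 h, at pH 7.4 (a higher number here means a more soluble compound, a lower number a less soluble compound), compound 1 gives 56000 nM, whereas compound 2 gives 740 nM, so compound 2 stands at the lower of the two numbers; the step of a 76-fold lower number from compound 1 to compound 2 (1.88 log units; beyond the scatter) is large and well beyond the scatter. Compound 3 `O=C(Nc1cccc(-c2nc3ccccc3s2)c1)c1cnc(Cl)s1` differs from compound 2 in one place: 2-chloro-1,3-thiazol-5-yl in place of 2-chloropyridin-4-yl on a carbonyl carbon. Among the measured compounds shown here, the only measured step concerns a very different exchange, in which an acid-bearing chain gave way to a chloropyridine ring; nothing measured here separates one chlorinated aromatic ring from another. For the measured compounds named here, with no step bearing directly on this change, compound 3 is expected to stay close to compound 2, with a step of a 1.1-fold lower number from compound 2 to compound 3 (0.02 log units; within the scatter) that is not expected to go beyond the scatter in either direction. Compound 3 is therefore estimated at 700 nM in this assay, within a range from 200 nM to 2500 nM.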

Compound 3, solubility: 940 nM
Estimate against measurement, compound 3: 1.3-fold (0.13 log units) below; measured number inside the range.
By their numbers in this assay, from the lowest: compounds 2 and 3 (each within the scatter of the next); then compound 1.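

On the carbonyl carbon, the five-membered 2-chloro-1,3-thiazol-5-yl ring takes the place of the six-membered 2-chloropyridin-4-yl ring with no readable change in this assay: the result is a 1.3-fold higher number from compound 2 to compound 3 (0.10 log units; within the scatter), even though the two groups differ in ring size, heavy atoms and hydrogen-bond acceptors. The comparison with the 2-carboxyethenyl group gives a 60-fold lower number from compound 1 to compound 3 (1.78 log units; beyond the scatter), so the large step first seen with the 2-chloropyridin-4-yl group now holds for two different chlorinated aromatic rings rather than for one. Nothing measured here explains why these two rings stand level or why both lie so far from compound 1.

On these data alone, whether the chlorine matters on either ring stays open, and a methyl group or an amine in its place would test that. As far as these compounds go, it also remains open whether the number for compound 1 depends on the carboxylic acid itself or on the chain that carries it, which a longer chain ending in a carboxylic acid or a simple ester on the same carbonyl carbon could help separate.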